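The source may hold more compounds than are shown below. What is called first, only, known or untested is meant among the compounds shown, and "the series" means these compounds.

Going by the values given here, of the two compounds measured so far, compound 2 `COc1ccc(OC)c(/C=C/C(=O)N/N=C/c2ccc(Cl)cc2)c1` stands lowest: in a functional assay on NCI-H322M cells (Homo sapiens) for antiproliferative activity, read by sulforhodamine B assay, with a stated time of 48 h (on this read-out higher numbers stand for weaker inhibition of growth and lower numbers for stronger inhibition of growth), compound 2 gives 666 nM, whereas compound 1 `COc1ccc(OC)c(/C=C/c2nnc(Nc3ccc(Cl)cc3)o2)c1` gives 30500 nM, a gap well beyond the usual scatter. Compound 3 `COc1ccc(OC)c(/C=C/C(=O)N/N=C/c2ccccc2)c1` is built from compound 2 by a single change, (hydrogen in place of chloro on an aromatic carbon). Among the compounds with values here, no measured pair shows this exact change, so its effect here is not known from data. For this change a modest step toward weaker growth inhibition is expected, a 2.3-fold higher number from compound 2 to compound 3 (0.35 log units; beyond the scatter), close to the scatter. Compound 3 is therefore estimated to give 1500 nM, with a likely range from 500 nM to 5000 nM.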

Compound 3, concentration for 50% growth inhibition: 5220 nM
Compound 3: middle estimate off by 3.5-fold (0.54 log units), on the low side; the whole stated range lies below it.
By their numbers in this assay, from the lowest: compound 2; then compound 3; then compound 1.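

Going by these compounds alone, replacing the chloro of the 4-chlorophenyl group with hydrogen gives the first direct reading of this position: growth inhibition in this assay weakens (a 7.8-fold higher number from compound 2 to compound 3 (0.89 log units; beyond the scatter)). The chloro, a single heavy atom, therefore matters here, which compound 1 and compound 2 could not show, as they differ in more than one place. Nothing available explains this step.

On these data alone, whether an amine or a carboxylic acid at this place would match the chloro remains open. So does whether the same change would have a similar effect on the core of compound 1.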